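This account rests on a few compounds, and the source may have more. Where it says the series, first, only, none or still open, it means among the compounds named here.

Measured so far in a functional assay on K562 cells (Homo sapiens) for cytotoxicity, read by MTT assay, with a stated time of 72 h; on this read-out higher numbers stand for weaker inhibition of growth and lower numbers for stronger inhibition of growth: compound 1 `CS/C(=N\C(=O)c1sccc1Cl)NC(=O)c1sccc1Cl` at 37000 nM; compound 2 `O=C(/N=C(/NC(=O)c1cc(-c2ccccc2)nc2ccccc12)[Se]Cc1ccccc1)c1cc(-c2ccccc2)nc2ccccc12` at 9060 nM.

Compound 2 has the lower of the two numbers, and its gap to compound 1 lies beyond the scatter. Compound 3 `CS/C(=N\C(=O)c1cc(-c2ccccc2)nc2ccccc12)NC(=O)c1cc(-c2ccccc2)nc2ccccc12` arises from compound 2 by a group of 2 heavy atoms (1 carbon, 1 sulfur; no ring) in place of a group of 8 heavy atoms (7 carbon, 1 selenium; one six-membered aromatic ring of carbon only), on a carbon with a double bond to nitrogen. Among the compounds with values here, compound 1 carries the same methylsulfanyl group on a different core, and in this assay compound 1 shows the higher number; no measured pair isolates this change on the core of compound 2. The step of a 2.2-fold higher number from compound 2 to compound 3 (0.34 log units; beyond the scatter) is expected to run toward a higher number, of moderate size, with wide uncertainty. Compound 3 is estimated at 20000 nM, within 6000 nM to 60000 nM.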

Compound 3, concentration for 50% growth inhibition: 34400 nM
Beside the measured number, compound 3's estimate is 1.7-fold (0.24 log units) below it, within the range that was stated.
By their numbers in this assay, from the lowest: compound 2; then compounds 3 and 1 (each within the scatter of the next).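

In this assay, within the data shown here, compounds 2 and 3 give the first pair that changes only the group on the carbon with a double bond to nitrogen, with the two amide-type nitrogens and the shared core held constant. On this core, methylsulfanyl in place of the selenium-bearing group of 8 heavy atoms gives a 3.8-fold higher number from compound 2 to compound 3 (0.58 log units; beyond the scatter), so this position alters the read-out. Nothing available explains the size or direction of this step.

The change replaces selenium and the aromatic ring together, so their contributions remain unseparated. Benzylsulfanyl and methylselanyl at this carbon remain open.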